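Replacing the Aryl Ether of Compound 3 with Chlorine

The source may report more compounds than this note shows. Statements on the series, on what has been measured and on what is new or still open speak of the compounds shown alone.

In a functional assay on HCT-116 cells (Homo sapiens) for inhibition, read by MTT assay, with a stated time of 48 h (a lower number here means a stronger inhibitor, a higher number a weaker inhibitor), the three measured compounds stand as follows: compound 1 `Cc1nnsc1CO/N=C/c1c(C)nn(C)c1Oc1cccc(C(F)(F)F)c1` gives 10300 nM; compound 2 `Cc1nnsc1CO/N=C/c1c(C)nn(C)c1Oc1ccc(OC(F)(F)F)cc1` gives 12800 nM; compound 3 `CCCc1nnsc1CO/N=C/c1c(C)nn(C)c1Oc1ccc(Cl)cc1` gives 19200 nM.

Compound 3 carries the highest of the three numbers, yet its gaps to compound 2 and to compound 1 both lie within the scatter, so no order among the three can be read from them. Compound 4 `CCCc1nnsc1CO/N=C/c1c(C)nn(C)c1Cl` differs from compound 3 by chloro in place of 4-chlorophenoxy on an aromatic carbon. Going by the values given here, no measured pair shows what such a change does, so its size and direction rest on nothing measured. Since all three measured compounds share the aryl ether, its loss is a deep cut, and a step toward a higher number, beyond the scatter, is expected: a 2.1-fold higher number from compound 3 to compound 4 (0.32 log units; beyond the scatter). Compound 4 is thus estimated at 40000 nM, in a range from 12000 nM to 130000 nM.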

Compound 4, half-maximal inhibitory concentration: > 50000 nM
Compound 4: only a limit was reported; the forecaster's own chance of this, stated with the estimate: 30%; at least 1.2-fold (0.09 log units) between middle value and limit.
By their numbers in this assay, from the lowest: compounds 1, 2 and 3 (each within the scatter of the next). At a limit, above all of these: compound 4.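

Chloro in place of 4-chlorophenoxy on this aromatic carbon gives an at least 2.6-fold higher number from compound 3 to compound 4 (0.41 log units; beyond the scatter) in this assay, the first change shown whose size lies beyond the scatter. For compound 4 the reading is only a limit, > 50000 nM. The position is therefore not indifferent to what it carries, and a lone chloro does not stand in for the aryl ether here.

From the compounds shown here alone, whether the ether oxygen or the phenyl ring counts more remains open, as does whether an amine or a directly attached phenyl at this carbon would bring the number back toward that of compound 3.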